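The compounds below may be only part of what the source reports. "The series", "measured", "known", "first", "only" and "open" are said of these compounds alone.

In a functional assay on MCF7 cells (Homo sapiens) for antiproliferative activity, read by MTT assay, with a stated time of 48 h (a higher number here means a weaker inhibitor, a lower number a stronger inhibitor), compound 1 `COc1ccc(-c2c(Nc3ccc(F)cc3)c3ccccc3oc2=O)cc1` gives 38500 nM and compound 2 `COc1ccc(-c2c(Nc3ccc(C)c(O)c3)c3ccccc3oc2=O)cc1` gives 12100 nM, the gap between them being a 3.2-fold lower number from compound 1 to compound 2 (0.50 log units; beyond the scatter). Compound 3 `COc1ccc(-c2c(Nc3ccc(NC(C)=O)cc3)c3ccccc3oc2=O)cc1` gives > 100000 nM, which is a limit of the assay and not a number. Its standing is therefore known only as the limit of > 100000 nM in this assay, at which 1 of the 3 values shown sits.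

Compound 4 `COc1ccc(-c2c(Nc3cccc(C(F)(F)F)c3)c3ccccc3oc2=O)cc1` has not yet been measured. It carries 3-(trifluoromethyl)phenyl in place of the 4-acetamidophenyl of compound 3 on the nitrogen: 3-(trifluoromethyl)phenyl in place of 4-acetamidophenyl on a nitrogen on an aromatic ring.

Going by the values given here, two measured steps bear on this change, both ending at compound 3 and both beyond the scatter: an at least 2.5-fold higher number from compound 1 to compound 3 (0.41 log units; beyond the scatter) and an at least 8.2-fold higher number from compound 2 to compound 3 (0.91 log units; beyond the scatter). Compound 4 gives up the 4-acetamidophenyl, so a lower number in this assay is expected, in the range seen for the two measured compounds without that group. Its size is uncertain, as only a limit exists at the starting point. The expected step is an at least 4.0-fold lower number from compound 3 to compound 4 (0.60 log units; beyond the scatter). For compound 4 the estimate is 25000 nM, with an expected range of 8000 nM to 80000 nM.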

Compound 4, half-maximal inhibitory concentration: 21600 nM
Compound 4: the middle estimate sits 1.2-fold (0.06 log units) above what was measured; the measured number falls inside the stated range.
By their numbers in this assay, from the lowest: compounds 2, 4 and 1 (each within the scatter of the next, the first and the last beyond it). At a limit, above all of these: compound 3.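

In this assay, replacing 4-acetamidophenyl with 3-(trifluoromethyl)phenyl on the nitrogen gives an at least 4.6-fold lower number from compound 3 to compound 4 (0.66 log units; beyond the scatter), so this position tolerates a group with no hydrogen-bond donor or acceptor, though the size of the step is only a bound. Compound 3 is held at a limit of the assay and not a number: the limit of > 100000 nM in this assay, at which 1 of the 4 values shown sits. The new group does not separate from the two others measured, with a 1.8-fold higher number from compound 2 to compound 4 (0.25 log units; within the scatter) and a 1.8-fold lower number from compound 1 to compound 4 (0.25 log units; within the scatter), and among these four compounds only the 4-acetamidophenyl stands apart.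

Compound 4 changes both the group and its place on the ring, and the compounds shown do not separate these two. On these data alone, how an amine or a carboxylic acid on this ring would read in this assay remains open.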